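The source may hold more compounds than are shown below. What is called first, only, known or untested is meant among the compounds shown, and "the series" means these compounds.

Measured compounds:
compound 1 `O=C(CN(c1ncnc2c1ncn2C1CCCCO1)C1CC1)N[C@@H](CO)C(=O)OCc1ccccc1`, in a functional assay on the whole organism (Tail, strain ICR) with Mus musculus as the target, in the tail flick test, with a stated time of 90 min, at a dose of 25 umol/kg by the oral route (on this read-out higher numbers stand for a stronger effect at the one dose given and lower numbers for a weaker effect), giving 32.2%
compound 2 `NC(=O)CC[C@H](NC(=O)CN(c1ncnc2c1ncn2C1CCCCO1)C1CC1)C(=O)OCc1ccccc1`, giving 37.8%
compound 3 `C[C@H](NC(=O)CN(c1ncnc2c1ncn2C1CCCCO1)C1CC1)C(=O)OCc1ccccc1`, giving 32.1%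

Compound 3 gives a number that sits within the scatter of both others. The two steps that end at it, a number 0.1 percentage points lower from compound 1 to compound 3 (within the scatter) and a number 5.7 percentage points lower from compound 2 to compound 3 (within the scatter), show that exchanging the group on the saturated chain carbon two bonds along the chain from an amide-type nitrogen and a carbonyl carbon has so far produced nothing beyond the scatter. Compound 4 `CC(C)(C)OC(=O)NCCCC[C@H](NC(=O)CN(c1ncnc2c1ncn2C1CCCCO1)C1CC1)C(=O)OCc1ccccc1` differs from compound 3 by 3-((tert-butoxycarbonyl)amino)propyl in place of hydrogen on a saturated chain carbon, two bonds along the chain from an amide-type nitrogen and a carbonyl carbon. Since the earlier exchanges at this place, compound 1 to compound 3 and compound 2 to compound 3, stayed within the scatter, the expected step is a number 0.9 percentage points higher from compound 3 to compound 4 (within the scatter), no change beyond the scatter. Compound 4 is therefore estimated at 33%, between 20% and 46%.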

Compound 4, a percentage reported as activity, at one dose (the size of the read-out at that dose, not a potency): 32.9%
Estimate against measurement, compound 4: 0.1 percentage points above; low and high end bracket the measured number.
By their numbers in this assay, from the lowest: compounds 3, 1, 4 and 2 (each within the scatter of the next).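

In this assay, placing 3-((tert-butoxycarbonyl)amino)propyl, with its 11 heavy atoms, on this chain carbon gives a number 0.8 percentage points higher from compound 3 to compound 4 (within the scatter) and thus no real change. The comparisons with the other two compounds agree: a number 4.9 percentage points lower from compound 2 to compound 4 (within the scatter) and a number 0.7 percentage points higher from compound 1 to compound 4 (within the scatter) also show that a group this large leaves the effect at this one dose unchanged. Nothing available explains this flat result.

Still open, from the compounds shown here alone, is whether an amine or a carboxylic acid on this chain carbon would move the number beyond the scatter.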